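A few compounds are considered here, and "the series" means these few. Any claim that something is new, unique, unknown or untested is made for them only; others in the source may bear on it.

Measured compounds:
- compound 1, `COc1nc2ccc(Br)cc2cc1[C@@H](c1ccnc(OC)c1OC)[C@@](O)(CCN(C)C)c1cccc(OC(F)F)c1`: 11 mL.min-1.g-1
- compound 2, `COc1nc2ccc(Br)cc2cc1[C@@H](c1ccnc(OC)c1OC)[C@@](O)(CCN(C)C)c1cccc(C#N)c1`: 19 mL.min-1.g-1
- compound 3, `COc1nc2ccc(Br)cc2cc1[C@@H](c1cncc(C)c1)[C@@](O)(CCN(C)C)c1cccc(F)c1`: 56 mL.min-1.g-1

In an ADME assay on microsomes from liver (Homo sapiens) for metabolic stability, with a stated time of 60 min, tested at 1 mg/mL (a lower number here means slower removal, a higher number faster removal of the compound), compound 3 stands highest of the three measured compounds: compound 2 lies nearest with a lower number, and compound 1 lies furthest, and both of those gaps are beyond the scatter. Compound 4, `COc1nc2ccc(Br)cc2cc1[C@@H](c1ccc(N(C)C)nc1)[C@@](O)(CCN(C)C)c1cccc(F)c1`, has not yet been measured in this assay. It differs from compound 3 in one place: 6-(dimethylamino)pyridin-3-yl in place of 5-methylpyridin-3-yl on a saturated chain carbon bound to an aromatic carbon and a saturated chain carbon.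

Going by the values given here, the only step measured so far is a 1.7-fold higher number from compound 1 to compound 2 (0.24 log units; within the scatter), and it concerns a different place on the shared core. Among the compounds with values here, no measured step touches the group that changes from compound 3 to compound 4, so there is nothing in the data that points to a direction for this change. The expectation for compound 4 therefore rests on the value of compound 3 alone, and the step from compound 3 to compound 4 is expected to be a 1.3-fold higher number from compound 3 to compound 4 (0.10 log units; within the scatter), that is, no step beyond the scatter. Compound 4 is accordingly estimated at 70 mL.min-1.g-1 in this assay, with a range from 30 mL.min-1.g-1 to 160 mL.min-1.g-1.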

Compound 4, intrinsic clearance in microsomes: 38 mL.min-1.g-1
Compound 4: the middle estimate sits 1.8-fold (0.27 log units) above what was measured; low and high end bracket the measured number.
By their numbers in this assay, from the lowest: compounds 1, 2, 4 and 3 (each within the scatter of the next, the first and the last beyond it).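

Going by these compounds alone, at this place, on a saturated chain carbon bound to an aromatic carbon and a saturated chain carbon, this assay gives the first reading of a change of group, with a 1.5-fold lower number from compound 3 to compound 4 (0.17 log units; within the scatter). The exchange of 5-methylpyridin-3-yl for 6-(dimethylamino)pyridin-3-yl, which brings a larger substituent and one more hydrogen-bond acceptor, therefore leaves the read-out within the usual scatter, so this pair shows that the position accepts this particular change without a clear shift in the number. Nothing available here bears on what lies behind this result.

From the compounds shown here alone, compound 1 and compound 2 carry a different group at this place, but they also differ from compound 3 and compound 4 at a second place on the shared core, so the part each place plays in the gap between those compounds stays open. Going by these compounds, it also remains open how this assay would respond at this place to a plain phenyl ring, to a morpholine in place of the dimethylamino group, or to a pyridine bearing a carboxylic acid.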